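Hydroxamate series on the shared core: step to compound 4

A few compounds are considered here, and "the series" means these few. Any claim that something is new, unique, unknown or untested is made for them only; others in the source may bear on it.

Measured so far in a functional assay on A549 cells (Homo sapiens) for antiproliferative activity, read by MTT assay; a lower number here means a stronger inhibitor, a higher number a weaker inhibitor:
compound 1 `COc1cc2c(Oc3ccc(NC(=O)Nc4ccccc4)cc3)ccnc2cc1OCCCCCCC(=O)NO` gives 1650 nM
compound 2 `COc1cc2c(Oc3ccc(NC(=O)Nc4cccc(C)c4)cc3)ccnc2cc1OCCCCCCC(=O)NO` gives 2010 nM
compound 3 `COc1cc2c(Oc3ccc(NC(=O)Nc4ccc(C(F)(F)F)cc4Cl)cc3)ccnc2cc1OCCCCCCC(=O)NO` gives 970 nM

Compound 1 stands second highest of the three numbers; a 1.2-fold higher number from compound 1 to compound 2 (0.09 log units; within the scatter) and a 1.7-fold lower number from compound 1 to compound 3 (0.23 log units; within the scatter) both stay within the scatter, and only a 2.1-fold lower number from compound 2 to compound 3 (0.32 log units; beyond the scatter) reaches beyond it. Compound 4 `COc1cc2c(Oc3ccc(NC(=O)NNC(=O)c4cccc(C)c4)cc3)ccnc2cc1OCCCCCCC(=O)NO` is not yet measured. Its change from compound 1 is ((3-methylphenyl)carbonyl)amino in place of phenyl on an amide-type nitrogen. For the measured compounds named here, no measured step touches that position in the same way; the nearest guide is a 1.2-fold higher number from compound 1 to compound 2 (0.09 log units; within the scatter), where a methyl entered without a step beyond the scatter, and the narrow spread across compounds 1 to 3. A larger change at the amide-type nitrogen is expected to give at most a modest step, likely upward, as a 1.5-fold higher number from compound 1 to compound 4 (0.18 log units; within the scatter). Compound 4 is therefore estimated at 2500 nM in this assay, between 900 nM and 7000 nM.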

Compound 4, half-maximal inhibitory concentration: 8190 nM
Estimate against measurement, compound 4: 3.3-fold (0.52 log units) below; the whole stated range lies below it.
By their numbers in this assay, from the lowest: compounds 3, 1 and 2 (each within the scatter of the next, the first and the last beyond it); then compound 4.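

In this assay, ((3-methylphenyl)carbonyl)amino on the amide-type nitrogen gives steps beyond the scatter from every earlier compound (a 5.0-fold higher number from compound 1 to compound 4 (0.70 log units; beyond the scatter); a 4.1-fold higher number from compound 2 to compound 4 (0.61 log units; beyond the scatter); an 8.4-fold higher number from compound 3 to compound 4 (0.93 log units; beyond the scatter)). Compound 4 is thus the weakest of the four, and this position accepts the aryl groups of compounds 1, 2 and 3 far better than this group. Nothing available explains the loss.

Still open, as far as these compounds go, is which part of the group carries the loss: the carbonyl, the added amino nitrogen or the methyl. A benzoylamino group without the methyl, or a plain amino group on that nitrogen, would help separate them.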